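Trifluoromethyl for fluoro on the aryl of compound 2

The source may report more compounds than this note shows. Statements on the series, on what has been measured and on what is new or still open speak of the compounds shown alone.

In a functional assay on PC-3 cells (Homo sapiens) for cytotoxicity, read by MTT assay, with a stated time of 72 h (on this read-out lower numbers stand for stronger inhibition and higher numbers for weaker inhibition), compound 1 `Cn1ccc2c(Oc3ccc(NC(=O)c4nn(-c5ccc(Br)cc5F)ccc4=O)cc3)ccnc21` gives 20500 nM, and compound 2 `Cn1ccc2c(Oc3ccc(NC(=O)c4nn(-c5ccc(Cl)c(F)c5)ccc4=O)cc3)ccnc21` gives 32700 nM. Compound 2 holds the higher of the two numbers, yet a 1.6-fold higher number from compound 1 to compound 2 (0.20 log units; within the scatter) separates them, so no order can be claimed. Compound 3 `Cn1ccc2c(Oc3ccc(NC(=O)c4nn(-c5ccc(Cl)c(C(F)(F)F)c5)ccc4=O)cc3)ccnc21` differs from compound 2 by trifluoromethyl in place of fluoro on an aromatic carbon. Going by the values given here, no measured step follows this change; the only step on hand swaps the whole aryl group and stays within the scatter. Compound 3 is therefore expected to show a 1.3-fold lower number from compound 2 to compound 3 (0.12 log units; within the scatter) in this assay, no shift beyond the scatter, at an estimated 25000 nM with a range from 8000 nM to 80000 nM.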

Compound 3, half-maximal inhibitory concentration: 10300 nM
For compound 3 the middle estimate is 2.4-fold (0.39 log units) above the measured one; measured number inside the range.
By their numbers in this assay, from the lowest: compounds 3, 1 and 2 (each within the scatter of the next, the first and the last beyond it).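

In this assay, trifluoromethyl in place of fluoro on the 4-chloro-3-fluorophenyl group gives the first step beyond the scatter among these compounds (a 3.2-fold lower number from compound 2 to compound 3 (0.50 log units; beyond the scatter)), so the number does respond to the group on this aromatic carbon, which the earlier whole-aryl swap did not show. The step between the two aryl groups stays within the scatter (a 2.0-fold lower number from compound 1 to compound 3 (0.30 log units; within the scatter)), so those two compounds cannot be ordered. Nothing measured here speaks to the cause of the shift. Going by these compounds, whether an amine, a nitrile or a longer chain on this carbon would move the number further stays open. So does whether the same change would give a similar step on the 4-bromo-2-fluorophenyl group.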